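The compounds below may be only part of what the source reports. "The series", "measured", "known", "first", "only" and "open" are said of these compounds alone.

Working notes on the series. Compound 1 `CC(C)C(C#Cc1cccc(C(=O)NCc2ccccc2C(F)(F)F)c1)N(O)C(N)=O` gives 500 nM in an assay for inhibition of Polyunsaturated fatty acid 5-lipoxygenase (Homo sapiens), read by HPLC, with stated times of 15 min and 10 min (on this read-out lower numbers stand for stronger inhibition and higher numbers for weaker inhibition), and stands second highest of the three numbers in hand. Compound 2 `C[C@H](C#Cc1cccc(C(=O)NCCC(c2ccc(F)cc2)c2ccc(OC(F)(F)F)cc2)c1)N(O)C(N)=O` gives 260 nM and compound 3 `C[C@H](C#Cc1cccc(C(=O)NCCC(c2ccccc2)c2ccc(S(N)(=O)=O)cc2)c1)N(O)C(N)=O` gives 1000 nM; both differences from compound 1 lie within the scatter, so no order among the three is claimed. Compound 4 `NC(=O)N(O)CC#Cc1cccc(C(=O)NCc2ccccc2C(F)(F)F)c1` has not been measured; its difference from compound 1 is hydrogen in place of isopropyl on a saturated chain carbon bound to an amide-type nitrogen and a triple-bonded carbon. Among the compounds with values here, no measured pair shows this change, so its size is unknown from the data. The expectation is a modest move toward a higher number, with the step from compound 1 to compound 4 estimated at a 3.0-fold higher number from compound 1 to compound 4 (0.48 log units; beyond the scatter). Compound 4 is thus expected near 1500 nM, between 500 nM and 5000 nM.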

Compound 4, half-maximal inhibitory concentration: 4000 nM
Beside the measured number, compound 4's estimate is 2.7-fold (0.43 log units) below it; the measured number falls inside the stated range.
By their numbers in this assay, from the lowest: compounds 2, 1 and 3 (each within the scatter of the next, the first and the last beyond it); then compound 4.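

Within the data shown here, this is the first single-place step, and it shows that the saturated chain carbon bound to an amide-type nitrogen and a triple-bonded carbon does not tolerate every substituent equally: hydrogen in place of isopropyl gives an 8.0-fold higher number from compound 1 to compound 4 (0.90 log units; beyond the scatter) in this assay on the core of compound 1. Nothing in hand bears on the reason for this step.

Open, going by these compounds, is where methyl, ethyl or cyclopropyl at this carbon would fall on the same core. Also open, on these data alone, is whether the same change gives a step of similar size with the amide side chains of compound 2 and compound 3.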